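Swapping Methyl for Fluoro in a Kinase Inhibitor Series

The compounds below may be only part of what the source reports. "The series", "measured", "known", "first", "only" and "open" are said of these compounds alone.

Three compounds have been measured in an assay on isolated protein for inhibition of Rho-associated protein kinase 2 (Homo sapiens), read by HTRF; a lower number here means a stronger inhibitor, a higher number a weaker inhibitor:

Compound 1, `O=C(c1ccc2c(c1)CC(c1nc3ccc(-c4cn[nH]c4)cc3c(=O)[nH]1)CO2)C1CC1`: 18 nM
Compound 2, `O=c1[nH]c(C2=Cc3ccccc3OC2)nc2ccc(-c3cn[nH]c3)cc12`: its result is a limit, > 5000 nM
Compound 3, `Cc1ccc2c(c1)CC(c1nc3ccc(-c4cn[nH]c4)cc3c(=O)[nH]1)CO2`: 6 nM

Compound 3 gives the lowest number; the nearest, compound 1, sits a 3.0-fold lower number from compound 1 to compound 3 (0.48 log units; beyond the scatter) away. Compound 2 stands at a limit of this assay, (the limit of > 5000 nM in this assay, at which 1 of the 3 values shown sits).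

Compound 4, `O=c1[nH]c(C2COc3ccc(F)cc3C2)nc2ccc(-c3cn[nH]c3)cc12`, differs from compound 3 by fluoro in place of methyl on an aromatic carbon. Within the data shown here, the one measured step at this aromatic carbon, a 3.0-fold lower number from compound 1 to compound 3 (0.48 log units; beyond the scatter), was modest, so a similar-sized or smaller move is expected here, likely toward a higher number. Compound 4 is estimated at 12 nM in this assay, within 4 nM to 40 nM, meaning an expected step of a 2.0-fold higher number from compound 3 to compound 4 (0.30 log units; within the scatter).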

Compound 4, half-maximal inhibitory concentration: 3 nM
For compound 4 the middle estimate is 4.0-fold (0.60 log units) above the measured one; measured number below the stated range.
By their numbers in this assay, from the lowest: compounds 4 and 3 (each within the scatter of the next); then compound 1. At a limit, above all of these: compound 2.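

Fluoro in place of methyl on this aromatic carbon gives a 2.0-fold lower number from compound 3 to compound 4 (0.30 log units; within the scatter), so the two groups cannot be told apart here. Fluoro in place of cyclopropylcarbonyl gives a 6.0-fold lower number from compound 1 to compound 4 (0.78 log units; beyond the scatter), matching what methyl did and leaving compound 1 with the highest number among the three groups at this position. Nothing measured here accounts for these steps.

Going by these compounds, whether chloro, methoxy or an amine on this carbon would keep the number as low remains open. So does whether a longer chain would be tolerated there.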